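Moving the chlorine on the phenylpiperazine of compound 1

The source may hold more compounds than are shown below. What is called first, only, known or untested is meant among the compounds shown, and "the series" means these compounds.

Measured compounds:
compound 1 `CCCc1nc(-c2ccccc2)c(CNCCN2CCN(c3ccccc3Cl)CC2)o1` – 4370 nM
compound 2 `CCCc1nc(-c2ccccc2)c(CNCCCN2CCN(c3ccc(F)cc3)CC2)o1` – 3210 nM
compound 3 `CCCc1nc(-c2ccccc2)c(CNCCCN2CCN(c3cccc(C(F)(F)F)c3)CC2)o1` – 650 nM

In an assay on HEK293 cells for inhibition of Voltage-dependent T-type calcium channel subunit alpha-1G (Homo sapiens), read by patch clamp (on this read-out higher numbers stand for weaker inhibition and lower numbers for stronger inhibition), compound 1 gives 4370 nM, the highest of the three numbers; compound 2 gives 3210 nM, which lies within the scatter of compound 1, while compound 3 gives 650 nM, well beyond it. The unmeasured compound 4 `CCCc1nc(-c2ccccc2)c(CNCCN2CCN(c3cccc(Cl)c3)CC2)o1` differs from compound 1 in one place: 3-chlorophenyl in place of 2-chlorophenyl on an amine nitrogen in a ring. Within the data shown here, the only measured step that touches the group on this ring nitrogen is a 4.9-fold lower number from compound 2 to compound 3 (0.69 log units; beyond the scatter), where a 3-(trifluoromethyl)phenyl replaced a 4-fluorophenyl and the number fell modestly. That step concerns different groups and a differently sized chain, so it bears on the present change only loosely. A modest step towards stronger inhibition is therefore expected, but a step within the scatter is also plausible. Compound 4 is estimated at 2000 nM, in a range from 800 nM to 5000 nM, which would be a step of a 2.2-fold lower number from compound 1 to compound 4 (0.34 log units; beyond the scatter).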

Compound 4, half-maximal inhibitory concentration: 1450 nM
Estimate against measurement, compound 4: 1.4-fold (0.14 log units) above; low and high end bracket the measured number.
By their numbers in this assay, from the lowest: compound 3; then compound 4; then compounds 2 and 1 (each within the scatter of the next).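

Among these compounds, this is the first pair here with identical atoms: only the place of the chlorine differs, and that alone gives a 3.0-fold lower number from compound 1 to compound 4 (0.48 log units; beyond the scatter) in this assay. The number therefore depends on where a substituent sits on this phenyl ring, not only on which substituent it carries. The earlier step, a 4.9-fold lower number from compound 2 to compound 3 (0.69 log units; beyond the scatter), could not show this, as the substituent and its place changed together there. Nothing at hand explains why the 3-chlorophenyl goes with the lower number.

As far as these compounds go, whether a methoxy group or a nitrile in place of the chlorine would respond to the same move remains open, as does how an unsubstituted phenyl would compare. Also open, from the compounds shown here alone, is whether moving the chlorine has a similar effect with the longer chain of compound 3.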